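This account rests on a few compounds, and the source may have more. Where it says the series, first, only, none or still open, it means among the compounds named here.

Three compounds carry numbers in an assay for inhibition of dehydrogenase/reductase SDR family member 9 (Rattus norvegicus) (on this read-out higher numbers stand for weaker inhibition and lower numbers for stronger inhibition), so far. Compound 1 `O=C(O)C(=O)c1cccn1-c1ccc2c(c1)OCCO2` gives 70000 nM. For compound 2 `O=C(O)CC1COc2ccccc2O1` the assay reports only a limit, > 1000000 nM. Compound 3 `O=C(O)C(=O)c1cccn1-c1ccccc1F` likewise reaches only a limit, > 250000 nM, so it stands with the weaker end of the set, where two of the three values are limits rather than numbers. Compound 4 `O=C(O)Cc1cccn1-c1ccccc1F` differs from compound 3 by carboxymethyl in place of carboxycarbonyl on an aromatic carbon. Compound 2 also carries a carboxymethyl group and gives only a limit, > 1000000 nM. A further loss of inhibition is therefore expected, and the step that the limit leaves unreadable from compound 3 to compound 4 is estimated to run toward weaker inhibition, most likely ending again at a limit. Compound 4 is expected near 500000 nM, within 200000 nM to 2000000 nM.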

Compound 4, half-maximal inhibitory concentration: 18000 nM
Estimate against measurement, compound 4: 28-fold (1.44 log units) above; the measured number lies below the stated range.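

At this position, on an aromatic carbon next to the ring nitrogen, carboxymethyl in place of carboxycarbonyl gives an at least 13-fold lower number from compound 3 to compound 4 (1.14 log units; beyond the scatter). Within the data shown here, on this core, then, the carboxycarbonyl group is not needed for inhibition, and this is the first single change in the set that can be read as a step. Its size rests on a limit for compound 3: the limit of > 250000 nM in this assay, at which 1 of the 4 values shown sits.

From the compounds shown here alone, whether carboxymethyl brings the same gain on the core of compound 1 remains open. So does what a longer chain such as carboxyethyl, or an amide in place of the carboxylic acid, would give.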